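Varying the aryl ether on a coumarin-linked imine series

The source may report more compounds than this note shows. Statements on the series, on what has been measured and on what is new or still open speak of the compounds shown alone.

The three measured compounds share one core and differ only in the aryl group carried on an oxygen on an aromatic ring. Compound 1 `Cc1nn(C)c(Oc2cccc(F)c2F)c1/C=N\CCCCCCOc1cc2oc(=O)cc(C)c2cc1Cl` gives in a functional assay on HepG2 cells (Homo sapiens) for antiproliferative activity, read by MTT assay, with a stated time of 72 h (on this read-out higher numbers stand for weaker inhibition and lower numbers for stronger inhibition), only a limit, > 25000 nM (the limit of > 25000 nM in this assay, at which 1 of the 3 values shown sits). Compound 2 `Cc1nn(C)c(Oc2ccc(I)cc2)c1/C=N\CCCCCCOc1cc2oc(=O)cc(C)c2cc1Cl` gives in this assay 14200 nM. Compound 3 `Cc1ccccc1Oc1c(/C=N\CCCCCCOc2cc3oc(=O)cc(C)c3cc2Cl)c(C)nn1C` gives in this assay 7830 nM, the lowest of the two numbers, with compound 2 nearest.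

Compound 4 `Cc1nn(C)c(Oc2ccc(OC(F)(F)F)cc2)c1/C=N\CCCCCCOc1cc2oc(=O)cc(C)c2cc1Cl` is not yet measured and differs from compound 3 in the same place as the other changes: 4-(trifluoromethoxy)phenyl in place of 2-methylphenyl on an oxygen on an aromatic ring. Among the measured compounds shown here, the steps that bear on it are an at least 3.1-fold lower number from compound 1 to compound 3 (0.50 log units; beyond the scatter), an at least 1.7-fold lower number from compound 1 to compound 2 (0.24 log units; that floor lies within the scatter) and a 1.8-fold lower number from compound 2 to compound 3 (0.26 log units; within the scatter). Compound 4, like compound 2, carries a 4-substituted phenyl, so compound 4 is expected to fall near compound 2, a step of a 1.5-fold higher number from compound 3 to compound 4 (0.19 log units; within the scatter) that stays within the scatter. Compound 4 is therefore estimated at 12000 nM, between 5500 nM and 25000 nM.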

Compound 4, half-maximal inhibitory concentration: 8160 nM
For compound 4 the middle estimate is 1.5-fold (0.17 log units) above the measured one; the range from low to high includes it.
By their numbers in this assay, from the lowest: compounds 3, 4 and 2 (each within the scatter of the next). At a limit, above all of these: compound 1.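

In this assay, exchanging 2-methylphenyl for 4-(trifluoromethoxy)phenyl on this oxygen gives a 1.0-fold higher number from compound 3 to compound 4 (0.02 log units; within the scatter), so a group with more heavy atoms and a hydrogen-bond acceptor leaves no readable difference here. Trifluoromethoxy in place of iodo on the aromatic carbon gives a 1.7-fold lower number from compound 2 to compound 4 (0.24 log units; within the scatter), while the comparison with the 2,3-difluorophenyl compound gives an at least 3.0-fold lower number from compound 1 to compound 4 (0.48 log units; beyond the scatter), a second step beyond the scatter that sets compound 1 apart. The reading for compound 1 is a limit and not a number: the limit of > 25000 nM in this assay, at which 1 of the 4 values shown sits.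

What the compounds shown leave open is whether fluorine itself or its placement on the ring separates compound 1 from compound 3 and compound 4. They also leave open whether an unsubstituted phenyl, or an aryl group carrying an amine or a carboxylic acid, would read alongside compound 3 and compound 4.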